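Cytotoxicity Limits Across an Amide Series

The compounds below may be only part of what the source reports. "The series", "measured", "known", "first", "only" and "open" are said of these compounds alone.

Compound 1 `CCOc1ccc(NC(=O)c2cccc(/C=C3\CC(=O)N(Cc4ccccc4)C3=O)c2)cc1` gives > 100000 nM in an ADME assay on NCM460 cells (Homo sapiens) for cytotoxicity, read by MTT assay, with a stated time of 72 h (a lower number here means a stronger inhibitor, a higher number a weaker inhibitor), a limit of the assay rather than a number.
Compound 2 `O=C(NCC1CCCCC1)c1cccc(/C=C2\CC(=O)N(c3ccccc3)C2=O)c1` gives > 100000 nM in this assay, again a limit.
Compound 3 `COc1ccc(NC(=O)c2cccc(/C=C3\CC(=O)N(c4ccccc4)C3=O)c2)c(C)c1` gives > 100000 nM in this assay, also a limit.

Compound 3 therefore stands at the same limit as every other value shown, and nothing places it above or below its neighbours. Among the compounds with values here, the one change between measured compounds, a step that the two limits leave unreadable from compound 2 to compound 3, cannot be read, because both ends of it are limits (the limit of > 100000 nM in this assay, at which 3 of the 3 values shown sit).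

Compound 4 `COc1ccc(OC)c(NC(=O)c2cccc(/C=C3\CC(=O)N(c4ccccc4)C3=O)c2)c1` is the next member. It differs from compound 3 in a single place: 2,5-dimethoxyphenyl in place of 4-methoxy-2-methylphenyl on an amide-type nitrogen. Within the data shown here, no measured step bears directly on this change; the only step available is unreadable, and all three values sit together at the limit (the limit of > 100000 nM in this assay, at which 3 of the 3 values shown sit). A new amide substituent of similar size on the same nitrogen is thus expected to behave as the three measured compounds do.

Compound 4 is expected to return a limit once more, and the expected step that the limit leaves unreadable from compound 3 to compound 4 is none beyond the scatter. The estimate for compound 4 in this assay is 150000 nM, with a range from 60000 nM to 400000 nM.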

Compound 4, half-maximal inhibitory concentration: > 100000 nM
Compound 4 gave a limit, no number; the forecaster's own chance of this, stated with the estimate: 85%; the middle value lies beyond the limit too.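

Within the data shown here, compound 4, like compound 2 and compound 3, gives only a limit and no number, so no new step to compound 4 can be read in this assay: the limit of > 100000 nM in this assay, at which 4 of the 4 values shown sit. The compounds shown leave open whether any other substituent on this amide nitrogen would give a readable number in this assay.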